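Swapping acetyl for an oxime: inhibition of paw edema

The source may report more compounds than this note shows. Statements on the series, on what has been measured and on what is new or still open speak of the compounds shown alone.

Compound 1 `C=CCn1c(SCC(=O)Nc2ccc(C(C)=O)cc2)nnc1-c1ccccc1` gives 48% in a functional assay on the whole organism (strain albino) for inhibition, with Rattus norvegicus as the target, read by paw edema, with stated times of 30 min and 1 h, at a dose of 0.28 mmol/kg by the oral route (a higher number here means more inhibition at the dose given (going by the name of the read-out), a lower number less inhibition), the lower of the two values measured, and compound 2 `COc1cc(-c2nnc(SCC(=O)Nc3ccc(/C(C)=N/O)cc3)n2-c2ccccc2)cc(OC)c1OC` gives 59% in this assay; the two compounds differ in several places, so their values are only compared, not traced to one change. Compound 3 `C=CCn1c(SCC(=O)Nc2ccc(/C(C)=N/O)cc2)nnc1-c1ccccc1` differs from compound 1 by a group of 4 heavy atoms (2 carbon, 1 nitrogen, 1 oxygen; no ring) in place of a group of 3 heavy atoms (2 carbon, 1 oxygen; no ring), on an aromatic carbon. Without a measured step for that single change, only a small shift is expected, within the scatter, from compound 1 to compound 3 a number 5 percentage points higher from compound 1 to compound 3 (within the scatter). Compound 3 is therefore estimated at 53%, between 40% and 66%.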

Compound 3, a percentage reported as inhibition, in the whole organism at one dose (the size of the read-out at that dose, not a potency): 61%
Compound 3: the middle estimate sits 8 percentage points below what was measured; the range from low to high includes it.
By their numbers in this assay, from the lowest: compound 1; then compounds 2 and 3 (each within the scatter of the next).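

Changing only the acetyl to the oxime, on an aromatic carbon para to a large group, gives a number 13 percentage points higher from compound 1 to compound 3 (beyond the scatter) in this assay, so inhibition at this dose does respond to the group at this position. Compound 1 and compound 2 differ in several places, which left this single change unread until now. Nothing measured here explains the gain. Going by these compounds, whether an amine or a carboxylic acid at this position would raise or lower inhibition stays open. So does whether the oxime gives a similar gain on other cores.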